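From isopropyl to cyclohexyl on a sulfur

The source may hold more compounds than are shown below. What is called first, only, known or untested is meant among the compounds shown, and "the series" means these compounds.

Measured in a functional assay on MT4 cells (Homo sapiens) for cytotoxicity; a lower number here means that less compound is tolerated, a higher number that more compound is tolerated:
Compound 1 `Cc1c(Cc2c(F)cccc2F)nc(SC(C)C)[nH]c1=O`: > 200000 nM, a limit of the assay
Compound 2 `CC(C)Sc1nc(O)cc(C(C)c2cccc3ccccc23)n1`: 119000 nM
Compound 3 `CCC(c1cc(O)nc(SC(C)C)n1)c1cccc2ccccc12`: 16900 nM

Of the two actual numbers, compound 3 holds the lower. Compound 4 `CCC(c1cc(O)nc(SC2CCCCC2)n1)c1cccc2ccccc12` differs from it in one place: cyclohexyl in place of isopropyl on a sulfur. That is cyclohexyl in place of isopropyl on a sulfur. Among the compounds with values here, the only measured step that bears on this is a 7.0-fold lower number from compound 2 to compound 3 (0.85 log units; beyond the scatter), with methyl in place of hydrogen on a saturated chain carbon. It lies at another place in the molecule, so it is a loose guide. The expected step is modest and toward a lower number: a 1.9-fold lower number from compound 3 to compound 4 (0.27 log units; within the scatter). Compound 4 is estimated at 9000 nM, within an expected range of 2500 nM to 35000 nM.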

Compound 4, half-maximal cytotoxic concentration: 23400 nM
Beside the measured number, compound 4's estimate is 2.6-fold (0.41 log units) below it, within the range that was stated.
By their numbers in this assay, from the lowest: compounds 3 and 4 (each within the scatter of the next); then compound 2. At a limit, above all of these: compound 1.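

In this assay, within the data shown here, cyclohexyl in place of isopropyl on the sulfur gives a 1.4-fold higher number from compound 3 to compound 4 (0.14 log units; within the scatter) and is the first reading at this position. A six-membered ring of carbon on the sulfur therefore brings no step beyond the scatter, whereas the chain carbon gave a 7.0-fold lower number from compound 2 to compound 3 (0.85 log units; beyond the scatter) in the earlier comparison. Nothing given here accounts for this result. From the compounds shown here alone, whether a longer chain or an amine in place of cyclohexyl on the sulfur would also stay within the scatter of compound 3 remains open.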